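Furan for Thiophene on the Sulfonamide Arm

A few compounds are considered here, and "the series" means these few. Any claim that something is new, unique, unknown or untested is made for them only; others in the source may bear on it.

Compound 1 `COc1cc2c(Oc3ccc(NC(=O)c4c(C)n(C)n(-c5ccccc5)c4=O)cc3F)ccnc2cc1OCCCN1CCN(C)CC1`: 2 nM
Compound 2 `COc1cc2c(Oc3ccc(NS(=O)(=O)c4cccc(-c5cnn(C)c5)c4)cc3F)ccnc2cc1OCCCN1CCN(C)CC1`: 6240 nM
Compound 3 `COc1cc2c(Oc3ccc(NS(=O)(=O)c4cccc(-c5ccsc5)c4)cc3F)ccnc2cc1OCCCN1CCN(C)CC1`: 1360 nM

In a functional assay on NCI-H1993 cells (Homo sapiens) for cytotoxicity, read by MTT assay, with a stated time of 48 h (a higher number here means a weaker inhibitor, a lower number a stronger inhibitor), compound 3 holds the second highest number of the three: compound 1 sits far lower, and compound 2 sits higher, both gaps beyond the scatter. Compound 4 `COc1cc2c(Oc3ccc(NS(=O)(=O)c4cccc(-c5ccco5)c4)cc3F)ccnc2cc1OCCCN1CCN(C)CC1` differs from compound 3 only by furan-2-yl in place of thiophen-3-yl on an aromatic carbon. Among the compounds with values here, the one measured step that bears on this change is a 4.6-fold lower number from compound 2 to compound 3 (0.66 log units; beyond the scatter), where one five-membered aromatic ring replaced another at the same carbon. Within the data shown here, no measured compound carries a furan, so the direction is open; the expected step of a 1.2-fold higher number from compound 3 to compound 4 (0.07 log units; within the scatter) is small, near the scatter. Compound 4 is therefore estimated at 1600 nM, within a range from 500 nM to 5000 nM.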

Compound 4, half-maximal inhibitory concentration: > 10000 nM
Compound 4 gave a limit, no number (the forecaster's own chance of this, stated with the estimate: 5%); middle value at least 6.2-fold (0.79 log units) from the limit.
By their numbers in this assay, from the lowest: compound 1; then compound 3; then compound 2. At a limit, above all of these: compound 4.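

In this assay, the change from thiophen-3-yl to furan-2-yl, with the heavy-atom count unchanged, gave an at least 7.3-fold higher number from compound 3 to compound 4 (0.86 log units; beyond the scatter), so this position on the sulfonamide arm is sensitive even to a swap between two five-membered aromatic rings with one hetero atom each. Set against 1-methyl-1H-pyrazol-4-yl, furan-2-yl gave an at least 1.6-fold higher number from compound 2 to compound 4 (0.20 log units; that floor lies within the scatter), which leaves the order of those two unsettled. The reading for compound 4 is a limit, not a number: the limit of > 10000 nM in this assay, at which 1 of the 4 values shown sits.

Still open, going by these compounds, is whether the hetero atom or the point of attachment carries this change; a furan-3-yl or thiophen-2-yl group would separate the two. On these data alone, how an amine on this ring would read also remains open.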